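A Bromophenyl Swap at the Assay's Upper Limit

This account rests on a few compounds, and the source may have more. Where it says the series, first, only, none or still open, it means among the compounds named here.

In an ADME assay on SH-SY5Y cells (Homo sapiens) for cytotoxicity, read by MTT assay, with a stated time of 72 h (on this read-out lower numbers stand for stronger inhibition and higher numbers for weaker inhibition), compound 2 `Cc1ccc(C(=O)N2CCN(CC(=O)N3CCN(CCCc4c[nH]c5ccccc45)CC3)CC2)cc1` gives > 200000 nM, which is a limit of the assay and not a number. Its close relative, compound 1 `O=C(CN1CCN(C(=O)c2ccc(Cl)cc2)CC1)N1CCN(CCCc2c[nH]c3ccccc23)CC1`, gives 139000 nM. Within the data shown here, the only measured step, an at least 1.4-fold higher number from compound 1 to compound 2 (0.15 log units; that floor lies within the scatter), has methyl in place of chloro on an aromatic carbon, so it offers a weak guide.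

Compound 3 `O=C(CN1CCN(C(=O)c2cccc(Br)c2)CC1)N1CCN(CCCc2c[nH]c3ccccc23)CC1` differs from compound 2 as follows: 3-bromophenyl in place of 4-methylphenyl on a carbonyl carbon. In words, this is 3-bromophenyl in place of 4-methylphenyl on a carbonyl carbon. Compound 3 loses the methyl and carries bromine, so it is expected to read close to compound 1 at 139000 nM. A reading at the limit of the assay also remains possible for compound 3. The expected change is small and toward a lower number, estimated as an at least 1.5-fold lower number from compound 2 to compound 3 (0.18 log units; that floor lies within the scatter). For compound 3, the estimated value is 130000 nM, with an expected range of 65000 nM to 200000 nM.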

Compound 3, half-maximal inhibitory concentration: 80500 nM
For compound 3 the middle estimate is 1.6-fold (0.21 log units) above the measured one; the measured number falls inside the stated range.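

In this assay, among these compounds, 3-bromophenyl in place of 4-methylphenyl on a carbonyl carbon gives an at least 2.4-fold lower number from compound 2 to compound 3 (0.39 log units; beyond the scatter), the first step here that clears the usual scatter. Compound 2 reads as a limit of the assay and not a number, and the true size of this step stays unknown because of that limit: the limit of > 200000 nM in this assay, at which 1 of the 3 values shown sits.

Set against the chlorine-bearing relative, 3-bromophenyl in place of 4-chlorophenyl gives a 1.7-fold lower number from compound 1 to compound 3 (0.24 log units; within the scatter), so this pair cannot be told apart.

That second step swaps the halogen and its place on the phenyl ring together, so neither change can be read alone, and 4-bromophenyl or 3-chlorophenyl would separate the two. Also open, from the compounds shown here alone, is how an amine or a carboxylic acid on that phenyl ring would read in this assay.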